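A few compounds are considered here, and "the series" means these few. Any claim that something is new, unique, unknown or untested is made for them only; others in the source may bear on it.

Going by the values given here, in a physicochemical assay for lipophilicity, at pH 7.4 (on this read-out lower numbers stand for lower lipophilicity and higher numbers for higher lipophilicity), compound 3 (`CNC(=O)c1sc(N2CC3CC2(CNC(=O)c2c[nH]c4ncccc24)C3)nc1C(F)(F)F`) gives 3.1, the lowest of the three numbers so far. Compound 1 (`CN(Cc1ccc2nccn2c1)c1nnc(-c2ccc(OC3CCCC3)cc2)o1`) gives 4.1, and compound 2 (`CNC(=O)c1sc(N2CC3CC2(CNC(=O)c2c[nH]c4ncc(C(F)(F)F)cc24)C3)nc1C(F)(F)F`) gives 4.2. Compound 4 (`CNC(=O)c1sc(N2CC3CC2(CNC(=O)c2c[nH]c4ncc(Cl)cc24)C3)nc1C(F)(F)F`) has not yet been measured. It differs from compound 3 by chloro in place of hydrogen on an aromatic carbon, which is chloro in place of hydrogen on an aromatic carbon. Among the compounds with values here, the one measured step bearing on this change is large, with hydrogen in place of trifluoromethyl on an aromatic carbon, a number 1.10 log units lower from compound 2 to compound 3 (beyond the scatter), and read in reverse it points to an expected rise for chloro, smaller but still beyond the scatter. The expected step is a number 0.70 log units higher from compound 3 to compound 4 (beyond the scatter). Compound 4 is estimated at 3.8, with an expected range of 3.4 to 4.2.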

Compound 4, distribution coefficient: 4
For compound 4 the middle estimate is 0.20 log units below the measured one; the measured number falls inside the stated range.
By their numbers in this assay, from the lowest: compound 3; then compounds 4, 1 and 2 (each within the scatter of the next).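

In this assay, this aromatic carbon now responds to a second group: chloro in place of hydrogen gives a number 0.90 log units higher from compound 3 to compound 4 (beyond the scatter) and so accounts for most of what trifluoromethyl added earlier. With chloro in place of trifluoromethyl there is a number 0.20 log units lower from compound 2 to compound 4 (within the scatter), so the read-out does not separate these two groups at this position. Nothing shown gives a reason for either step. Going by these compounds, what an amine, a methoxy group or a carboxylic acid on this carbon would give remains open, as does whether the chloro step would carry over to another core.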